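The compounds below may be only part of what the source reports. "The series", "measured", "known", "first", "only" and "open" are said of these compounds alone.

Compound 1 `Oc1cccc(-c2cc(-c3cccc(O)c3)nc(-c3ccccc3O)c2)c1`, compound 2 `Oc1ccccc1-c1cc(-c2ccccc2O)nc(-c2ccccc2O)c1` and compound 3 `Oc1ccc(-c2cc(-c3cccc(O)c3)cc(-c3cccc(O)c3)n2)cc1` were examined in a functional assay on HCT-15 cells (Homo sapiens) for cytotoxicity, read by CCK-8 assay, with a stated time of 4 days; on this read-out lower numbers stand for stronger inhibition and higher numbers for weaker inhibition. In this assay compound 1 gives only a limit, > 50000 nM (the limit of > 50000 nM in this assay, at which 1 of the 3 values shown sits). Compound 2 gives 2180 nM, and compound 3 gives 3090 nM, two numbers within the scatter of each other. The change 4-hydroxyphenyl in place of 2-hydroxyphenyl on an aromatic carbon brought an at least 16-fold lower number from compound 1 to compound 3 (1.20 log units; beyond the scatter). How the cores of compound 1 and compound 2 differ is not broken down here. Compound 4 `Oc1ccc(-c2cc(-c3ccccc3O)cc(-c3ccccc3O)n2)cc1` is not yet measured; it differs from compound 2 by 4-hydroxyphenyl in place of 2-hydroxyphenyl on an aromatic carbon, the same kind of change, though here the place is meta to two 2-hydroxyphenyl groups rather than to two 3-hydroxyphenyl groups. A smaller step is expected, a 1.5-fold lower number from compound 2 to compound 4 (0.16 log units; within the scatter), because compound 2 already gives 2180 nM. Compound 4 is estimated at 1500 nM, between 400 nM and 6000 nM.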

Compound 4, half-maximal inhibitory concentration: 8240 nM
Beside the measured number, compound 4's estimate is 5.5-fold (0.74 log units) below it, outside the stated range (above it).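

In this assay the same change of 2-hydroxyphenyl to 4-hydroxyphenyl brought a 3.8-fold higher number from compound 2 to compound 4 (0.58 log units; beyond the scatter), so it did not carry over from one core to the other in size or in direction: the same change on two cores in this assay, an at least 16-fold lower number (1.20 log units; beyond the scatter) from compound 1 to compound 3 and a 3.8-fold higher number (0.58 log units; beyond the scatter) from compound 2 to compound 4, at least 61-fold (1.78 log units) apart, beyond the scatter of two such steps. Compound 1 gives only a limit, > 50000 nM. This single pair of steps shows that the outcome of the change depends on the core in these compounds, but it does not show which difference between the cores lies behind this or how the change would go on any further core.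

All four compounds carry hydroxyphenyl groups only. From the compounds shown here alone, whether a methoxy group or an amine in place of the hydroxyl would follow either step remains open.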